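Replacing a Chlorophenyl Arm on a Shared Scaffold

A few compounds are considered here, and "the series" means these few. Any claim that something is new, unique, unknown or untested is made for them only; others in the source may bear on it.

Compound 1 `COc1ccc(-c2c(C)nn(-c3nc(-c4ccc(Cl)c(Cl)c4)c(SC(C)C)s3)c2C(=O)O)cc1` gives 2100 nM in a functional assay on BJAB cells (Homo sapiens) for antiproliferative activity, with a stated time of 4 days; a lower number here means that less compound is needed, a higher number that more compound is needed for the effect.
Compound 2 `Cc1nn(-c2nc(-c3ccc(Cl)c(Cl)c3)c(SC(C)C)s2)c(C(=O)O)c1-c1ccc(Cl)cc1` gives 2500 nM in this assay.

For the measured compounds named here, compound 2 stands beside compound 1, the only other measured compound, and the two are separated by a 1.2-fold higher number from compound 1 to compound 2 (0.08 log units; within the scatter). Compound 3 `COc1cc(C#N)cc(-c2c(C)nn(-c3nc(-c4ccc(Cl)c(Cl)c4)c(SC(C)C)s3)c2C(=O)O)c1` differs from compound 2 in one place: 3-cyano-5-methoxyphenyl in place of 4-chlorophenyl on an aromatic carbon. Going by the values given here, the single measured step, a 1.2-fold higher number from compound 1 to compound 2 (0.08 log units; within the scatter), exchanged a group at this same place and stayed within the scatter, so a comparably small outcome is expected, although the entering group is larger and the expectation rests on one step alone. Compound 3 is therefore expected to give 2500 nM (range 1000 nM to 6500 nM) in this assay, an estimated step of no change at the digits printed from compound 2 to compound 3 (within the scatter).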

Compound 3, half-maximal effective concentration: 5200 nM
Compound 3: middle estimate off by 2.1-fold (0.32 log units), on the low side, within the range that was stated.
By their numbers in this assay, from the lowest: compounds 1 and 2 (each within the scatter of the next); then compound 3.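

At this place on the shared core, the earlier exchange of chloro for methoxy stayed within the scatter, whereas 3-cyano-5-methoxyphenyl brings a 2.1-fold higher number from compound 2 to compound 3 (0.32 log units; beyond the scatter) and a 2.5-fold higher number from compound 1 to compound 3 (0.39 log units; beyond the scatter) as modest steps beyond it. The number in this assay therefore does respond to the aryl group held here, though only by a small margin. No measurement at hand accounts for the shift.

From the compounds shown here alone, whether the nitrile or the methoxy carries the step stays open. So does what a phenyl group bearing an amine would give here.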